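Aryl variation at the saturated ring carbon: M14 growth inhibition

A few compounds are considered here, and "the series" means these few. Any claim that something is new, unique, unknown or untested is made for them only; others in the source may bear on it.

Measured so far:
compound 1, `Cc1cc(O)c(C2=NN(c3ccc(S(N)(=O)=O)cc3)C(c3ccccc3O)C2)cc1Cl`, 3400 nM
compound 2, `Cc1cc(O)c(C2=NN(c3ccc(S(N)(=O)=O)cc3)C(/C=C/c3ccccc3)C2)cc1Cl`, 19300 nM
compound 3, `COc1ccc(C2CC(c3cc(Cl)c(C)cc3O)=NN2c2ccc(S(N)(=O)=O)cc2)cc1OC`, 7260 nM

All three share one core and differ only in the group carried on the saturated ring carbon. In a functional assay on M14 cells (Homo sapiens) for antiproliferative activity, with a stated time of 48 h (on this read-out higher numbers stand for weaker inhibition of growth and lower numbers for stronger inhibition of growth), compound 1 gives the lowest number of the three, compound 2 the highest, and compound 3 stands second highest, separated from both by steps beyond the scatter: a 2.1-fold higher number from compound 1 to compound 3 (0.33 log units; beyond the scatter) and a 2.7-fold lower number from compound 2 to compound 3 (0.42 log units; beyond the scatter).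

Compound 4, `COc1ccc(C2CC(c3cc(Cl)c(C)cc3O)=NN2c2ccc(S(N)(=O)=O)cc2)c(OC)c1OC`, differs from compound 3 in one place: methoxy in place of hydrogen on an aromatic carbon. The measured steps that bear on this position, a 2.1-fold higher number from compound 1 to compound 3 (0.33 log units; beyond the scatter) and a 2.7-fold lower number from compound 2 to compound 3 (0.42 log units; beyond the scatter), each exchange the whole aryl group and both came out modest, one raising and one lowering the number. For the measured compounds named here, no measured step adds a single methoxy to an aryl that is already present, so the direction of this smaller change cannot be read from the data. A step within the scatter, or only just beyond it, is therefore expected, that is a 1.0-fold lower number from compound 3 to compound 4 (0.02 log units; within the scatter).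

Compound 4 is estimated at 7000 nM in this assay. The expected range for compound 4 runs from 3000 nM to 17000 nM.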

Compound 4, concentration for total growth inhibition: 4290 nM
For compound 4 the middle estimate is 1.6-fold (0.21 log units) above the measured one, and the stated range covers the measured number.
By their numbers in this assay, from the lowest: compounds 1, 4 and 3 (each within the scatter of the next, the first and the last beyond it); then compound 2.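

Working notes on the aryl group: in this assay the first single-group change on this aryl gives a 1.7-fold lower number from compound 3 to compound 4 (0.23 log units; within the scatter), so 3,4-dimethoxyphenyl and 2,3,4-trimethoxyphenyl cannot be told apart on this read-out. The 2,3,4-trimethoxyphenyl group also stays within the scatter of 2-hydroxyphenyl, with a 1.3-fold higher number from compound 1 to compound 4 (0.10 log units; within the scatter), whereas a 4.5-fold lower number from compound 2 to compound 4 (0.65 log units; beyond the scatter) leaves compound 2 separated from each of the other three by a step beyond the scatter, so among these compounds only the 2-phenylethenyl group stands apart. No measurement accompanies these numbers that would explain any of these steps.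

The compounds shown leave open whether an amine or a carboxylic acid on this aryl would shift the number beyond the scatter, as the added methoxy does not. They also leave open whether the higher number of compound 2 goes with the 2-phenylethenyl group specifically, since neither a benzyl group nor a longer chain on the saturated ring carbon appears among them.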